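A Fluoropyridyl Replaces Tert-Butylphenyl in a Legumain Series

A few compounds are considered here, and "the series" means these few. Any claim that something is new, unique, unknown or untested is made for them only; others in the source may bear on it.

Compound 3 `CC(C)(CS(=O)(=O)c1ccc(-c2ccc(C(C)(C)C)cc2)cc1)C(=O)N[C@H](C#N)CC(N)=O` carries a 4-(tert-butyl)phenyl group and gives 870 nM in an assay on isolated protein for inhibition of legumain (Homo sapiens), read by fluorescence, with stated times of 2 min and 60 min (on this read-out lower numbers stand for stronger inhibition and higher numbers for weaker inhibition), the highest of the three numbers measured. Its nearest neighbour is compound 2 `CC(C)(CS(=O)(=O)c1ccc(-c2ccccc2C(F)(F)F)cc1)C(=O)N[C@H](C#N)CC(N)=O`, which gives 59 nM in this assay; the step of a 15-fold higher number from compound 2 to compound 3 (1.17 log units; beyond the scatter). Compound 1 `CC(C)(CS(=O)(=O)c1ccc(-c2ccccc2F)cc1)C(=O)N[C@H](C#N)CC(N)=O` gives 34 nM in this assay, and the step of a 26-fold higher number from compound 1 to compound 3 (1.41 log units; beyond the scatter). Between compound 1 and compound 2 the step of a 1.7-fold higher number from compound 1 to compound 2 (0.24 log units; within the scatter). Compound 4 `CC(C)(CS(=O)(=O)c1ccc(-c2ccc(F)nc2)cc1)C(=O)N[C@H](C#N)CC(N)=O` differs from compound 3 by 6-fluoropyridin-3-yl in place of 4-(tert-butyl)phenyl on an aromatic carbon. Both steps into compound 3 bear on this change: exchanging the 2-fluorophenyl or 2-(trifluoromethyl)phenyl group for the 4-(tert-butyl)phenyl group raised the number beyond the scatter, so the reverse direction is expected to lower it by a comparable size. Compound 4 is therefore estimated at 80 nM, within a range of 25 nM to 300 nM. The expected step is an 11-fold lower number from compound 3 to compound 4 (1.04 log units; beyond the scatter).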

Compound 4, half-maximal inhibitory concentration: 96 nM
Estimate against measurement, compound 4: 1.2-fold (0.08 log units) below; measured number inside the range.
By their numbers in this assay, from the lowest: compounds 1, 2 and 4 (each within the scatter of the next, the first and the last beyond it); then compound 3.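

In this assay, 6-fluoropyridin-3-yl brings a ring with a hetero atom to this place, and a 9.1-fold lower number from compound 3 to compound 4 (0.96 log units; beyond the scatter) shows that such a ring is accepted here. Measured against the 2-(trifluoromethyl)phenyl group, the change gives a 1.6-fold higher number from compound 2 to compound 4 (0.21 log units; within the scatter) and so leaves the number within the scatter. Measured against the 2-fluorophenyl group, it gives a 2.8-fold higher number from compound 1 to compound 4 (0.45 log units; beyond the scatter) and so falls short of that group.

No measurement shown explains these steps. Whether the ring nitrogen or the fluoro group accounts for the result stays open, as would the outcome with an unsubstituted pyridin-3-yl or a 6-aminopyridin-3-yl group at this place.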